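Benzylsulfanyl for methylamino on the shared core

The compounds below may be only part of what the source reports. "The series", "measured", "known", "first", "only" and "open" are said of these compounds alone.

Compound 3 `CNc1nc2c(Cl)c(Cl)ccc2n1COCCO` gives only a limit in a functional assay on KB cells (Homo sapiens) for inhibition (on this read-out lower numbers stand for stronger inhibition and higher numbers for weaker inhibition), namely > 100000 nM. Compound 1 `OCCOCn1c(Cl)nc2c(Cl)c(Cl)ccc21` likewise stops at a limit, > 100000 nM. Compound 2 `Nc1nc2c(Cl)c(Cl)ccc2n1COCCO` also yields a limit, > 100000 nM. The steps a step that the two limits leave unreadable from compound 1 to compound 2, a step that the two limits leave unreadable from compound 1 to compound 3 and a step that the two limits leave unreadable from compound 2 to compound 3 therefore carry no size, since (the limit of > 100000 nM in this assay, at which 3 of the 3 values shown sit). Compound 4 `OCCOCn1c(SCc2ccccc2)nc2c(Cl)c(Cl)ccc21` differs from compound 3 by benzylsulfanyl in place of methylamino on an aromatic carbon. Among the compounds with values here, none of the measured steps bears on this change, and the three limits give no foothold for a direction. Compound 4 is accordingly expected to remain near the same limit, with an estimate of 100000 nM ranging from 20000 nM to 300000 nM. The implied step a number no higher from compound 3 to compound 4 (the limit leaves the size open) is expected to stay within the scatter, though a measurable number below the limit cannot be excluded.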

Compound 4, half-maximal inhibitory concentration: 35000 nM
Compound 4: middle estimate off by 2.9-fold (0.46 log units), on the high side, within the range that was stated.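

Benzylsulfanyl on this aromatic carbon between two ring nitrogen atoms gives the only readable change in this assay, and it holds against all three groups shown there: methylamino (an at least 2.8-fold lower number from compound 3 to compound 4 (0.45 log units; beyond the scatter)), amino (an at least 2.8-fold lower number from compound 2 to compound 4 (0.45 log units; beyond the scatter)) and chloro (an at least 2.8-fold lower number from compound 1 to compound 4 (0.45 log units; beyond the scatter)). The steps among compound 1, compound 2 and compound 3 cannot be read. Each new step is a bound, so its full size stays undefined.

As far as these compounds go, whether the lower number follows the sulfur or the benzyl remains open. Benzylamino or methylsulfanyl at this position would separate the two.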